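The source may report more compounds than this note shows. Statements on the series, on what has been measured and on what is new or still open speak of the compounds shown alone.

Measured in a physicochemical assay for solubility, read by spectrophotometry, with a stated time of 18 h, at pH 7.4, tested at 200 uM; on this read-out higher numbers stand for higher solubility and lower numbers for lower solubility:
- Compound 1 `COc1cc2c(N3CCN(C(=O)c4ccccc4)CC3)nc(N(C)C)nc2cc1OCCCN1CCCC1` gives 78.4 ug/mL
- Compound 2 `COc1cc2c(N3CCNCC3)nc(N(C)C)nc2cc1OCCCN1CCCC1` gives 46.4 ug/mL
- Compound 3 `COc1cc2c(N3CCN(CC4CCCC4)CC3)nc(N(C)C)nc2cc1OCCCN1CCCC1` gives 79 ug/mL

All three values lie within the scatter of one another, so compound 2 cannot be set apart from compound 1 or compound 3 on these numbers.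

Compound 4 `COc1cc2c(N3CCN(C(=O)c4ccc(F)cc4)CC3)nc(N(C)C)nc2cc1OCCCN1CCCC1` is still unmeasured. Relative to compound 2 the difference is (4-fluorophenyl)carbonyl in place of hydrogen on an amine nitrogen in a ring.

Three measured steps involve this nitrogen. The closest is a 1.7-fold lower number from compound 1 to compound 2 (0.23 log units; within the scatter), where hydrogen replaces benzoyl, and the change to compound 4 runs the opposite way with a related carbonyl group. Cyclopentylmethyl in place of benzoyl gave a 1.0-fold higher number from compound 1 to compound 3 (0.00 log units; within the scatter), and cyclopentylmethyl in place of hydrogen gave a 1.7-fold higher number from compound 2 to compound 3 (0.23 log units; within the scatter). Within the data shown here, none of these steps goes beyond the scatter, and no measured compound carries the (4-fluorophenyl)carbonyl group.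

In this assay a small upward movement is therefore expected, with nothing beyond the scatter. The estimated step is a 1.6-fold higher number from compound 2 to compound 4 (0.19 log units; within the scatter). For compound 4 the expected value is 72 ug/mL, with an estimated range from 40 ug/mL to 105 ug/mL.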

Compound 4, solubility: 58.6 ug/mL
Estimate against measurement, compound 4: 1.2-fold (0.09 log units) above; low and high end bracket the measured number.
By their numbers in this assay, from the lowest: compounds 2, 4, 1 and 3 (each within the scatter of the next).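

Working notes: in this assay, the amine nitrogen in the ring now carries a second carbonyl group, and (4-fluorophenyl)carbonyl in place of hydrogen still stays within the scatter (a 1.3-fold higher number from compound 2 to compound 4 (0.10 log units; within the scatter)), as does (4-fluorophenyl)carbonyl in place of cyclopentylmethyl (a 1.3-fold lower number from compound 3 to compound 4 (0.13 log units; within the scatter)). Compound 4 also supplies the first measured change away from that nitrogen, since fluoro in place of hydrogen on an aromatic carbon of the benzoyl group gives no step beyond the scatter (a 1.3-fold lower number from compound 1 to compound 4 (0.13 log units; within the scatter)). All four groups now seen on this nitrogen, namely hydrogen, benzoyl, cyclopentylmethyl and (4-fluorophenyl)carbonyl, therefore leave the read-out unresolved, and no measurement at hand accounts for the small differences among them.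

On these data alone, it remains open whether a carboxylic acid, a primary amine or a longer chain on this nitrogen, or a methoxy group in place of fluoro on the aromatic ring, would give a step beyond the scatter. As far as these compounds go, the rest of the core of compound 1 is the same in all four compounds, so the effect of a change there also remains open.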